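Chalcone-pyrazole series: dichlorophenyl to difluorophenyl swap

The source may hold more compounds than are shown below. What is called first, only, known or untested is meant among the compounds shown, and "the series" means these compounds.

Measured so far:
compound 1 `COc1ccc(-c2cc(/C=C/C(=O)c3ccc(N)cc3)[nH]n2)cc1` — 15000 nM
compound 2 `COc1cc(-c2cc(/C=C/C(=O)c3ccc(Cl)c(Cl)c3)[nH]n2)cc(OC)c1OC` — 54600 nM

Of the compounds shown here, two have been measured in a functional assay on RXF 393 cells (Homo sapiens) for inhibition, read by sulforhodamine B assay, with a stated time of 48 h; a higher number here means that more compound is tolerated, a lower number that less compound is tolerated. Compound 1 gives 15000 nM there. Compound 2 gives 54600 nM in this assay, the higher of the two numbers; the gap to compound 1 lies beyond the scatter of the method, so compound 2 is the one of which more is tolerated. Compounds 1 and 2 differ in more than one place, so no single-point step can be read from them.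

Compound 3 `COc1cc(-c2cc(/C=C/C(=O)c3ccc(F)c(F)c3)[nH]n2)cc(OC)c1OC` is not yet measured. It differs from compound 2 in one place: 3,4-difluorophenyl in place of 3,4-dichlorophenyl on a carbonyl carbon. Going by the values given here, no measured pair shows a change of this kind, so the direction of the step cannot be taken from the data. The step from compound 2 to compound 3 is expected to stay within the scatter, with a 1.1-fold lower number from compound 2 to compound 3 (0.04 log units; within the scatter) as the estimated shift. Compound 3 is therefore expected to give about 50000 nM in this assay, within a range of 18000 nM to 140000 nM.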

Compound 3, concentration lethal to 50% of the cells: 54100 nM
The estimate for compound 3 lay 1.1-fold (0.03 log units) below the measured number, and the stated range covers the measured number.
By their numbers in this assay, from the lowest: compound 1; then compounds 3 and 2 (each within the scatter of the next).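

In this assay, going by these compounds alone, 3,4-difluorophenyl in place of 3,4-dichlorophenyl on a carbonyl carbon gives a 1.0-fold lower number from compound 2 to compound 3 (0.00 log units; within the scatter), the first single-point step that can be read. Within the data shown here, at this position, on the core of compound 2, exchanging one halogen pair for the other therefore leaves no readable change in the read-out, although the result covers only this one exchange. No measurement bearing on the reason for this outcome is at hand.

Compound 1 differs from compound 2 and from compound 3 in more than one place, so no step involving it can be read, and the compounds shown do not separate the contribution of this position from that of the rest of the molecule. As far as these compounds go, it remains open whether the number would also hold with a group of a different kind on this phenyl ring, such as a carboxylic acid, a nitrile or a dimethylamino group, or with the plain unsubstituted phenyl, on the core of compound 2.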